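Taking the side chain off compound 2

The source may hold more compounds than are shown below. What is called first, only, known or untested is meant among the compounds shown, and "the series" means these compounds.

In a functional assay on ECa-109 cells (Homo sapiens) for antiproliferative activity, read by MTT assay, with a stated time of 48 h (a lower number here means a stronger inhibitor, a higher number a weaker inhibitor), compound 2 `CN(C)CCCn1nc(C2=C(c3cn(C)c4ccccc34)C(=O)NC2=O)c2cccnc21` gives > 100000 nM, which is a limit of the assay and not a number. Compound 1 `Cn1cc(C2=C(c3nn(CCCn4cccc4)c4ncccc34)C(=O)NC2=O)c2ccccc21` gives > 100000 nM, again a limit. Within the data shown here, the only measured step, a step that the two limits leave unreadable from compound 1 to compound 2, therefore has no readable size, and the limit of > 100000 nM in this assay, at which 2 of the 2 values shown sit, sums up all that is known so far.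

Compound 3 `Cn1cc(C2=C(c3n[nH]c4ncccc34)C(=O)NC2=O)c2ccccc21` loses the side chain altogether: hydrogen in place of 3-(dimethylamino)propyl on an aromatic nitrogen. It has hydrogen in place of 3-(dimethylamino)propyl on an aromatic nitrogen. Among the measured compounds shown here, neither measured compound carries that hydrogen, so no measured step speaks directly to this change. With only limits to go on, a clear gain in this assay is not expected, and the estimated step of an at least 1.2-fold lower number from compound 2 to compound 3 (0.09 log units; that floor lies within the scatter) has no firm direction. For compound 3 the expected value is 80000 nM, with an estimated range from 20000 nM to 200000 nM.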

Compound 3, half-maximal inhibitory concentration: 46100 nM
Beside the measured number, compound 3's estimate is 1.7-fold (0.24 log units) above it; the measured number falls inside the stated range.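

Among these compounds, this is the first readable change at this position, the aromatic nitrogen of the five-membered ring. In this assay, hydrogen in place of 3-(dimethylamino)propyl gives an at least 2.1-fold lower number from compound 2 to compound 3 (0.33 log units; beyond the scatter), and hydrogen in place of 3-(1H-pyrrol-1-yl)propyl gives an at least 2.1-fold lower number from compound 1 to compound 3 (0.33 log units; beyond the scatter). Both steps start from a limit and not a number, so only their smallest size is known, and the step between the two compounds with side chains still cannot be read, which leaves this summary: the limit of > 100000 nM in this assay, at which 2 of the 3 values shown sit.

The compounds shown leave open whether a single methyl on that nitrogen would read like the hydrogen of compound 3 or like the longer chains. They also leave open how a shorter chain, or a propyl chain ending in a carboxylic acid, would read in this assay.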